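Nitrophenyl pyrazole series: halogen swap on the phenyl ring

This account rests on a few compounds, and the source may have more. Where it says the series, first, only, none or still open, it means among the compounds named here.

Measured so far in a functional assay on AGS cells (Homo sapiens) for inhibition, read by MTT assay, with a stated time of 48 h; a higher number here means a weaker inhibitor of growth, a lower number a stronger inhibitor of growth:
Compound 1, `O=[N+]([O-])c1cccc(-c2cc(-c3ccccc3)n[nH]2)c1`: 11400 nM
Compound 2, `O=[N+]([O-])c1ccc(-c2cc(-c3ccc(F)cc3)n[nH]2)cc1`: 18300 nM

Compound 2 gives the higher of the two numbers in this assay, but compound 1 sits within the usual scatter of it, so the two values do not separate. For the measured compounds named here, both compounds are weak inhibitors of growth on this scale, and no step between them is counted, since they differ in more than one place.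

Compound 3, `O=[N+]([O-])c1ccc(-c2cc(-c3ccc(Br)cc3)n[nH]2)cc1`, is not yet measured. It differs from compound 2 by bromo in place of fluoro on an aromatic carbon. Going by the values given here, nothing in the measured pair speaks to the effect of exchanging one halogen for another at this position; the only comparison available, compound 1 against compound 2, mixes two changes and lies within the scatter anyway.

Among the compounds with values here, with no prior step to lean on, the expectation for compound 3 is a number close to that of compound 2, and the step from compound 2 to compound 3 is estimated at a 1.4-fold lower number from compound 2 to compound 3 (0.15 log units; within the scatter), which is no more than the scatter allows. Compound 3 is therefore expected to give about 13000 nM in this assay, with a plausible range from 5000 nM to 35000 nM.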

Compound 3, concentration for 50% growth inhibition: 14600 nM
Compound 3: middle estimate off by 1.1-fold (0.05 log units), on the low side, and the stated range covers the measured number.
By their numbers in this assay, from the lowest: compounds 1, 3 and 2 (each within the scatter of the next).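

In this assay, for the compounds shown here, the exchange of 4-fluorophenyl for 4-bromophenyl gives a 1.3-fold lower number from compound 2 to compound 3 (0.10 log units; within the scatter) and provides the first comparison that differs in one place only. Unlike the pair of compound 1 and compound 2, which mixes two changes, this step isolates the halogen on the aromatic carbon, and fluoro and bromo do not separate at this position. No supporting measurement bears on this result.

Because this is a single pair, it shows only that these two halogens are not distinguished here, and it sets no trend for other halogens or for other groups at this position; an amine, a carboxylic acid, a methoxy group or a longer alkyl chain in place of the halogen could still separate from compound 2 and compound 3 in this assay. Going by these compounds alone, the contribution of the halogen relative to hydrogen also remains unread, as does that of the nitro group, since compound 1 differs from compound 2 in more than one place and no compound here carries an amine or a nitrile in place of the nitro group.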